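Swapping Methoxy for Bromo on a Weak Deacetylase Inhibitor

The source may report more compounds than this note shows. Statements on the series, on what has been measured and on what is new or still open speak of the compounds shown alone.

In an assay for inhibition of histone deacetylase 8 (Homo sapiens), read by fluorescence, with stated times of 15 min and 60 min (on this read-out lower numbers stand for stronger inhibition and higher numbers for weaker inhibition), compound 1 `Nc1ccccc1NC(=O)c1ccc(CNC2=N[C@@H](Cc3ccccc3)CS2)cc1` gives 34900 nM, and compound 3 `CC(=O)N1C(NCc2ccc(C(=O)Nc3ccccc3N)cc2)=NC(=O)C1Cc1ccccc1` gives 22700 nM. Compound 2 `COc1ccc(NC(=O)c2ccc(CNc3nccc(-c4cccnc4)n3)cc2)c(N)c1` reaches only a limit of the assay, > 20000 nM, a value that is the limit of > 20000 nM in this assay, at which 1 of the 3 values shown sits. Compound 4 `Nc1cc(Br)ccc1NC(=O)c1ccc(CNc2nccc(-c3cccnc3)n2)cc1` is compound 2 with bromo in place of methoxy on an aromatic carbon. Among the compounds with values here, no pair of measured compounds shows this change, so there is no measured step to lean on; all three measured values sit at the weak end of this assay's read-out. The expected step is a step that the limit leaves unreadable from compound 2 to compound 4, nothing beyond the usual scatter. Compound 4 is therefore estimated at 30000 nM, within a range from 8000 nM to 120000 nM, with a fair chance that this assay again returns only a limit.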

Compound 4, half-maximal inhibitory concentration: > 20000 nM
Compound 4 ended at the assay's limit; the forecaster's own chance of this, stated with the estimate: 60%; the middle value does not contradict the limit.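

Compound 2 and compound 4 both stop at a limit of this assay rather than at a number, so no step can be read between them: the limit of > 20000 nM in this assay, at which 2 of the 4 values shown sit.

The compounds shown leave open whether bromo or methoxy gives the stronger inhibition.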